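Sulfonyl substituent and permeability across the series

The compounds below may be only part of what the source reports. "The series", "measured", "known", "first", "only" and "open" are said of these compounds alone.

Compound 3 `CS(=O)(=O)NC(=O)c1ccc(Nc2nc(NC3(c4ccc(Cl)cc4)CC3)nc(OCC(F)(F)F)n2)cc1` gives 11 nm/s in a physicochemical assay for permeability, using PAMPA, at pH 7.4 (on this read-out higher numbers stand for higher permeability and lower numbers for lower permeability), the lowest of the three numbers measured. Compound 1 `O=C(NS(=O)(=O)c1ccccc1)c1ccc(Nc2nc(NC3(c4ccc(Cl)cc4)CC3)nc(OCC(F)(F)F)n2)cc1` gives 182 nm/s and compound 2 `O=C(NS(=O)(=O)CCNCc1ccccc1)c1ccc(Nc2nc(NC3(c4ccc(Cl)cc4)CC3)nc(OCC(F)(F)F)n2)cc1` gives 49 nm/s in this assay. The steps of a 3.7-fold lower number from compound 1 to compound 2 (0.57 log units; beyond the scatter) and a 4.5-fold lower number from compound 2 to compound 3 (0.65 log units; beyond the scatter) place compound 3 beyond the scatter of both others.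

Compound 4 `Cc1ccccc1S(=O)(=O)NC(=O)c1ccc(Nc2nc(NC3(c4ccc(Cl)cc4)CC3)nc(OCC(F)(F)F)n2)cc1` differs from compound 3 by 2-methylphenyl in place of methyl on a sulfonyl sulfur. The closest measured precedent is a 17-fold lower number from compound 1 to compound 3 (1.22 log units; beyond the scatter), which records the change when methyl replaces phenyl on that sulfur. Compound 4 runs the same exchange in the opposite direction, with 2-methylphenyl entering where methyl leaves, so that step read backwards points to a large increase in this assay. The step of a 3.7-fold lower number from compound 1 to compound 2 (0.57 log units; beyond the scatter) bears on it only loosely, as a second change at the same sulfur that also moved the number well beyond the scatter.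

Compound 4 is therefore expected to give about 160 nm/s in this assay, with a plausible range of 60 nm/s to 400 nm/s. The expected step is a 15-fold higher number from compound 3 to compound 4 (1.16 log units; beyond the scatter).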

Compound 4, apparent permeability: 265 nm/s
Beside the measured number, compound 4's estimate is 1.7-fold (0.22 log units) below it; the range from low to high includes it.
By their numbers in this assay, from the lowest: compound 3; then compound 2; then compounds 1 and 4 (each within the scatter of the next).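

In this assay the new result shows that 2-methylphenyl on the sulfonyl sulfur gives a 24-fold higher number from compound 3 to compound 4 (1.38 log units; beyond the scatter) and so stands with phenyl, whose exchange for methyl gave a 17-fold lower number from compound 1 to compound 3 (1.22 log units; beyond the scatter) in the opposite direction. The methyl on the aromatic carbon adds no readable change, since a 1.5-fold higher number from compound 1 to compound 4 (0.16 log units; within the scatter) leaves compound 4 and compound 1 level on this read-out. With a 5.4-fold higher number from compound 2 to compound 4 (0.73 log units; beyond the scatter) as well, 2-methylphenyl also separates from 2-(benzylamino)ethyl, so compound 1 and compound 4 both stand beyond the scatter of compound 2 and compound 3.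

Still open, on these data alone, is whether a methoxy group or a chlorine in place of that methyl, or a longer alkyl chain without the benzylamino group on the sulfur, would hold the number at this level. No evidence on hand gives a cause for any of these steps.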